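Nitro shift in benzenesulfonanilides: extending to the tolyl core

The compounds below may be only part of what the source reports. "The series", "measured", "known", "first", "only" and "open" are said of these compounds alone.

Compound 1 `O=S(=O)(Nc1ccccc1)c1ccccc1` is the parent. In an ADME assay, compound 1 gives 9.1. Compound 2 `O=[N+]([O-])c1cccc(NS(=O)(=O)c2ccccc2)c1` carries nitro in place of hydrogen on an aromatic carbon; in this assay compound 2 gives 7.93, and the step is a number 1.17 log units lower from compound 1 to compound 2 (beyond the scatter). Compound 3 `Cc1ccc(NS(=O)(=O)c2ccccc2)cc1` differs from compound 1 by methyl in place of hydrogen on an aromatic carbon; in this assay compound 3 gives 9.34, the step being a number 0.24 log units higher from compound 1 to compound 3 (within the scatter).

Compound 4 `Cc1ccc(NS(=O)(=O)c2cccc([N+](=O)[O-])c2)cc1` is not yet measured. It differs from compound 3 by nitro in place of hydrogen on an aromatic carbon, the same change seen from compound 1 to compound 2, here made on the core of compound 3. Among the measured compounds shown here, with only one prior instance of this change, the step from compound 3 to compound 4 is expected to be a number 1.14 log units lower from compound 3 to compound 4 (beyond the scatter), resting on the step of a number 1.17 log units lower from compound 1 to compound 2 (beyond the scatter). Compound 4 is therefore estimated at 8.2 in this assay.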

Compound 4, acid dissociation constant: 7.8
The estimate for compound 4 lay 0.40 log units above the measured number; measured number inside the range.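

In this assay, nitro in place of hydrogen on an aromatic carbon again gives a large step, a number 1.54 log units lower from compound 3 to compound 4 (beyond the scatter), and the two instances agree: the same change on two cores in this assay, a number 1.17 log units lower (beyond the scatter) from compound 1 to compound 2 and a number 1.54 log units lower (beyond the scatter) from compound 3 to compound 4, 0.37 log units apart, within the scatter of two such steps. The change therefore carries from the core of compound 1 to the core of compound 3 in direction and, within the scatter, in size. Two instances on two similar cores do not show that this holds on other cores, and they do not explain the size of the step.

From the compounds shown here alone, it remains open whether an amine, a carboxylic acid or trifluoromethyl in place of the nitro would give a step of similar size. Also open, going by these compounds, is how the nitro step behaves on a core with a longer chain in place of methyl.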